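This account rests on a few compounds, and the source may have more. Where it says the series, first, only, none or still open, it means among the compounds named here.

Measured compounds in a functional assay on L02 cells (Homo sapiens) for inhibition, read by MTT assay, with a stated time of 48 h; on this read-out lower numbers stand for stronger inhibition and higher numbers for weaker inhibition:

compound 1, `COc1ccc(CNC(=O)/C=C/c2coc3cc(O)ccc3c2=O)cc1`, gives > 200000 nM
compound 2, `O=C(/C=C/c1coc2cc(O)ccc2c1=O)NCc1ccc(F)cc1`, gives > 200000 nM

The value shown for compound 1 is a limit of the assay, not a number. The value shown for compound 2 is also a limit, not a number. So compound 2 stands at the top of the measured range, where no concentration could be read. For the measured compounds named here, the one step between measured compounds, a step that the two limits leave unreadable from compound 1 to compound 2, puts a fluoro in place of a methoxy on an aromatic carbon, and its size cannot be read because both values sit at the limit of > 200000 nM in this assay, at which 2 of the 2 values shown sit.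

Compound 3, `O=C(/C=C/c1coc2cc(O)ccc2c1=O)Nc1ccccc1`, differs from compound 2 by phenyl in place of 4-fluorobenzyl on an amide-type nitrogen. Going by the values given here, this change has no measured counterpart among the compounds above, and the only measured step gives no readable size, so no direction or size can be taken from the data. With both known values at the limit, the step of a number no higher from compound 2 to compound 3 (the limit leaves the size open) is expected to show no change beyond the scatter. Compound 3 is therefore estimated at 200000 nM, with a range from 50000 nM to 1000000 nM, and most likely again only a limit.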

Compound 3, half-maximal inhibitory concentration: > 200000 nM
Compound 3: no number, only a limit; the forecaster's own chance of this, stated with the estimate: 80%; the middle value lies on the limit itself.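

In this assay compound 3 gives > 200000 nM and this is a limit of the assay, not a number. For the compounds shown here, no step from compound 2 to compound 3 can therefore be read, and all three compounds sit at the same limit: the limit of > 200000 nM in this assay, at which 3 of the 3 values shown sit. The compounds shown leave open which change to the structure, if any, would give a readable concentration.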